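Diamine side chains on the shared core

The source may hold more compounds than are shown below. What is called first, only, known or untested is meant among the compounds shown, and "the series" means these compounds.

In a functional assay on MDA-MB-435 cells (Homo sapiens) for cytotoxicity, read by MTT assay, with a stated time of 72 h (a higher number here means a weaker inhibitor, a lower number a stronger inhibitor), compound 3 `N[C@H]1CC[C@H](Nc2c(C(=O)NCc3ccc(F)cc3)nc(Br)c3cccnc23)CC1` gives 6000 nM, the lowest of the two numbers seen; its nearest neighbour is compound 2 `Nc1ccc(Nc2c(C(=O)NCc3ccc(F)cc3)nc(Br)c3cccnc23)cc1`, which in this assay gives 7000 nM, and the pair sits within the scatter a 1.2-fold lower number from compound 2 to compound 3 (0.07 log units; within the scatter). Compound 1 `CS(=O)(=O)Oc1c(C(=O)NCc2ccc(F)cc2)nc(Br)c2cccnc12` gives only a limit in this assay, > 20000 nM (the limit of > 20000 nM in this assay, at which 1 of the 3 values shown sits). From that limit the steps of an at least 2.8-fold lower number from compound 1 to compound 2 (0.45 log units; beyond the scatter) and an at least 3.3-fold lower number from compound 1 to compound 3 (0.52 log units; beyond the scatter) are the only sized moves seen. Compound 4 `CNCCCNc1c(C(=O)NCc2ccc(F)cc2)nc(Br)c2cccnc12` differs from compound 3 by 3-(methylamino)propyl in place of 4-aminocyclohexyl on a nitrogen on an aromatic ring: the six-membered non-aromatic ring leaves and a chain with no ring enters, the donor and acceptor count unchanged. Since the aryl and cyclohexyl diamines read alike, no step beyond the scatter is expected, no change at the digits printed from compound 3 to compound 4 (within the scatter). Compound 4 is estimated at 6000 nM, between 2500 nM and 15000 nM.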

Compound 4, half-maximal inhibitory concentration: 11000 nM
Estimate against measurement, compound 4: 1.8-fold (0.26 log units) below; the measured number falls inside the stated range.
By their numbers in this assay, from the lowest: compounds 3, 2 and 4 (each within the scatter of the next). At a limit, above all of these: compound 1.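

In this assay, the open chain 3-(methylamino)propyl on this nitrogen reads alike with both ring diamines (a 1.8-fold higher number from compound 3 to compound 4 (0.26 log units; within the scatter); a 1.6-fold higher number from compound 2 to compound 4 (0.20 log units; within the scatter)), so a ring at this place is not needed to hold the number in this range. Against the methylsulfonyloxy compound, the step (an at least 1.8-fold lower number from compound 1 to compound 4 (0.25 log units; that floor lies within the scatter)) has a floor that, unlike those of the two ring diamines, stays within the scatter. Compound 1 stands only as a limit: the limit of > 20000 nM in this assay, at which 1 of the 4 values shown sits.

As far as these compounds go, whether the side-chain amine matters at all stays open; a hydroxyl in its place would test this. From the compounds shown here alone, a longer chain or a dimethylamino end is also open.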